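A few compounds are considered here, and "the series" means these few. Any claim that something is new, unique, unknown or untested is made for them only; others in the source may bear on it.

Measured compounds:
- compound 1 `CC(C)OC(=O)N1CCC2(CC1)CC(CCCOc1ccc(C(N)=O)c(F)c1)C2`: 52 nM
- compound 2 `CC(C)OC(=O)N1CCC2(CC1)CC(CCCOc1ccc(C(=O)N(C)C3CC3)c(F)c1)C2`: 67 nM
- compound 3 `CC(C)OC(=O)N1CCC2(CC1)CC(CCCOc1ccc(C(=O)N3CCCC3)c(F)c1)C2`: 29 nM

In a functional assay on cells for agonist activity at Glucose-dependent insulinotropic receptor (Homo sapiens), read by HTRF and cAMP accumulation, with a stated time of 30 min (on this read-out higher numbers stand for an effect only at larger amounts of compound and lower numbers for an effect already at smaller amounts), compound 3 gives the lowest number of the three. The two steps that reach it are a 1.8-fold lower number from compound 1 to compound 3 (0.25 log units; within the scatter) and a 2.3-fold lower number from compound 2 to compound 3 (0.36 log units; beyond the scatter), so only the latter counts as a real separation. Compound 4 `CC(C)OC(=O)N1CCC2(CC1)CC(CCCOc1ccc(C(=O)N3CC(O)C3)c(F)c1)C2` is not yet measured. It differs from compound 3 in one place: 3-hydroxyazetidin-1-yl in place of pyrrolidin-1-yl on a carbonyl carbon.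

Going by the values given here, two measured steps bear on this change, since both alter the group on the same carbonyl carbon of the shared core. The step of a 1.8-fold lower number from compound 1 to compound 3 (0.25 log units; within the scatter) and the step of a 2.3-fold lower number from compound 2 to compound 3 (0.36 log units; beyond the scatter) show that swapping the amide substituent moves the number only a little, with the pyrrolidin-1-yl group giving the lowest value seen. Among the compounds with values here, compound 4 keeps a cyclic amine at this position but shrinks the ring and brings in a hydrogen-bond donor and acceptor that none of the three measured groups carry, so no measured step covers that part of the change. The author therefore expects a small loss for compound 4 relative to compound 3, of about a 1.6-fold higher number from compound 3 to compound 4 (0.19 log units; within the scatter), and estimates compound 4 at 45 nM in this assay , with a range from 18 nM to 120 nM.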

Compound 4, half-maximal effective concentration: 40 nM
Compound 4: the middle estimate sits 1.1-fold (0.05 log units) above what was measured; the range from low to high includes it.
By their numbers in this assay, from the lowest: compounds 3, 4, 1 and 2 (each within the scatter of the next, the first and the last beyond it).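

In this assay, going by these compounds alone, the 3-hydroxyazetidin-1-yl group is the first group on this carbonyl carbon to carry a hydrogen-bond donor and acceptor, and a four-membered ring takes the place of the five-membered one, yet the swap stays within the scatter (a 1.4-fold higher number from compound 3 to compound 4 (0.14 log units; within the scatter)). The same holds when compound 4 is set against the two other amides (a 1.7-fold lower number from compound 2 to compound 4 (0.22 log units; within the scatter); a 1.3-fold lower number from compound 1 to compound 4 (0.11 log units; within the scatter)), so it cannot be told apart from any of the three earlier compounds, even though compound 2 and compound 3 are separated beyond the scatter. Thus this place on the carbonyl carbon accepts a hydroxyl-bearing four-membered ring with no change that can be read in this assay, and nothing available here explains that result.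

The swap alters ring size and adds the hydroxyl at once, so the compounds shown leave the two contributions unseparated; azetidin-1-yl without the hydroxyl and 3-hydroxypyrrolidin-1-yl would each isolate one of them. They also leave open how a larger ring such as piperidin-1-yl or a carboxylic acid on the azetidine ring would read at this place.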